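The source may report more compounds than this note shows. Statements on the series, on what has been measured and on what is new or still open speak of the compounds shown alone.

Measured so far:
- compound 1 `CCN(CC)Cc1c(O)c([C@H]2CCN(C)C[C@H]2O)c2oc(C)cc(=O)c2c1O` gives 24%
- compound 2 `Cc1cc(=O)c2c(O)c(CN3CCCC3)c(O)c([C@H]3CCN(C)C[C@H]3O)c2o1` gives 12%

Among the compounds with values here, both values come from a functional assay on MCF7 cells (Homo sapiens) for inhibition, read by MTT assay, with a stated time of 48 h, tested at 10 uM (on this read-out higher numbers stand for more inhibition of growth at the one concentration tested and lower numbers for less inhibition of growth), and are the only numbers available for the series. Compound 2 holds the lower of the two. Compound 3 `Cc1cc(=O)c2c(O)c(CN3CCCC3CO)c(O)c([C@H]3CCN(C)C[C@H]3O)c2o1` is still to be measured and differs from compound 2 by hydroxymethyl in place of hydrogen on a saturated ring carbon.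

Within the data shown here, the only measured step that bears on this change is a number 12 percentage points lower from compound 1 to compound 2 (beyond the scatter), with pyrrolidin-1-yl in place of diethylamino, which is modest but beyond the scatter. That step shows that a change in this amine group can shift the read-out. Among the measured compounds shown here, it gives no direction for the new group, since no measured compound carries a hydroxymethyl on the pyrrolidine ring. A shift of similar or smaller size is therefore the most that can be expected, and a step beyond the scatter is not expected. The estimate is a number 4 percentage points higher from compound 2 to compound 3 (within the scatter), a slight rise that stays within the scatter. For compound 3 the expected value is 16%, with an estimated range from 5% to 30%.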

Compound 3, percent growth inhibition at one concentration: 22%
The estimate for compound 3 lay 6 percentage points below the measured number; measured number inside the range.
By their numbers in this assay, from the lowest: compounds 2, 3 and 1 (each within the scatter of the next, the first and the last beyond it).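

In this assay, hydroxymethyl on the saturated ring carbon next to the ring nitrogen gives a number 10 percentage points higher from compound 2 to compound 3 (within the scatter), so this ring carbon carries the added group without a step beyond the scatter in either direction. Against diethylamino, the 2-(hydroxymethyl)pyrrolidin-1-yl group gives a number 2 percentage points lower from compound 1 to compound 3 (within the scatter), so the gap beyond the scatter in a number 12 percentage points lower from compound 1 to compound 2 (beyond the scatter) is not repeated for the substituted ring, although compound 3 lies within the scatter of both other compounds and a real gain from the hydroxymethyl can be neither claimed nor excluded. No measurement at hand offers an explanation for these numbers.

Going by these compounds, whether a methoxymethyl, an aminomethyl or a carboxylic acid in place of the hydroxymethyl on this ring carbon would move the number beyond the scatter remains open. Also open, on these data alone, is how these amines compare over a range of concentrations, as each reading in this assay comes from a single tested concentration.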